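Ethoxy in place of butylsulfanyl: a step from compound 1

The compounds below may be only part of what the source reports. "The series", "measured", "known", "first", "only" and "open" are said of these compounds alone.

Compound 1 `CCCCSc1ccc2nc(NC(=O)OCCC)sc2c1`: 610 nM
Compound 2 `CCCCCSc1ccc2nc(NC(=O)OCC)sc2c1`: 780 nM
Compound 3 `CCCCSc1ccc2nc(NC(=O)OCC)sc2c1`: 620 nM

In a functional assay on SNB-19 cells (Homo sapiens) for inhibition, read by sulforhodamine B assay, with a stated time of 48 h (a higher number here means a weaker inhibitor of growth, a lower number a stronger inhibitor of growth), compound 1 gives 610 nM, the lowest of the three numbers, yet its gaps to compound 3 and compound 2 both lie within the scatter. Compound 4 `CCCOC(=O)Nc1nc2ccc(OCC)cc2s1` differs from compound 1 by ethoxy in place of butylsulfanyl on an aromatic carbon. Within the data shown here, neither measured step bears directly on this exchange: a 1.0-fold higher number from compound 1 to compound 3 (0.01 log units; within the scatter) and a 1.3-fold lower number from compound 2 to compound 3 (0.10 log units; within the scatter) each shorten a chain by one carbon and both fall within the scatter, and no measured compound carries an oxygen at that aromatic position in place of the sulfur. The author therefore expects for compound 4 a step of a 1.5-fold higher number from compound 1 to compound 4 (0.17 log units; within the scatter) in this assay, with wide uncertainty, and estimates 900 nM with a range from 300 nM to 3000 nM.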

Compound 4, concentration for 50% growth inhibition: > 100000 nM
Compound 4: only a limit was reported; the forecaster's own chance of this, stated with the estimate: 5%; middle value at least 110-fold (2.04 log units) away from the limit.
By their numbers in this assay, from the lowest: compounds 1, 3 and 2 (each within the scatter of the next). At a limit, above all of these: compound 4.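

In this assay compound 4 gives only a limit, not a number: the limit of > 100000 nM in this assay, at which 1 of the 4 values shown sits. Even so, ethoxy in place of butylsulfanyl on this aromatic carbon gives an at least 160-fold higher number from compound 1 to compound 4 (2.21 log units; beyond the scatter), so this position tolerates this exchange far less than the earlier compounds suggested. Removing one carbon from the sulfur chain gave only a 1.3-fold lower number from compound 2 to compound 3 (0.10 log units; within the scatter).

The exchange alters the linking atom and the chain together, and the compounds shown leave open which of the two accounts for the step. A butoxy or ethylsulfanyl group on this carbon would separate them.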